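Swapping the difluorophenyl group from compound 2 to compound 3

A few compounds are considered here, and "the series" means these few. Any claim that something is new, unique, unknown or untested is made for them only; others in the source may bear on it.

Compound 1 `O=C1c2ccccc2C(=O)N1CCOC(=S)N(C(=O)c1cccc([N+](=O)[O-])c1)c1ccc(Cl)cc1`: 18000 nM
Compound 2 `O=C1c2ccccc2C(=O)N1CCOC(=S)N(C(=O)c1cccc(F)c1F)c1ccc(Cl)cc1`: 58000 nM

In an ADME assay on MT4 cells (Homo sapiens) for cytotoxicity, read by MTT assay (on this read-out lower numbers stand for higher toxicity in this test and higher numbers for lower toxicity in this test), compound 2 holds the higher of the two numbers at 58000 nM. Compound 3 `O=C1c2ccccc2C(=O)N1CCOC(=S)N(C(=O)c1ccc(F)c(F)c1)c1ccc(Cl)cc1` differs from it by one change: 3,4-difluorophenyl in place of 2,3-difluorophenyl on a carbonyl carbon. For the measured compounds named here, only one measured step bears on this, and only indirectly: a 3.2-fold higher number from compound 1 to compound 2 (0.51 log units; beyond the scatter). That modest step replaced a different group on a carbonyl carbon, whereas here both groups are difluorophenyl. No change beyond the scatter is therefore expected, and the estimated step is a 1.2-fold lower number from compound 2 to compound 3 (0.06 log units; within the scatter). Compound 3 is expected at 50000 nM, with an estimated range from 22000 nM to 100000 nM.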

Compound 3, half-maximal cytotoxic concentration: 52000 nM
The estimate for compound 3 lay 1.0-fold (0.02 log units) below the measured number, within the range that was stated.
By their numbers in this assay, from the lowest: compound 1; then compounds 3 and 2 (each within the scatter of the next).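

In this assay, 3,4-difluorophenyl in place of 2,3-difluorophenyl on the carbonyl carbon gives a 1.1-fold lower number from compound 2 to compound 3 (0.05 log units; within the scatter), so this read-out does not separate the two difluorophenyl groups. The gap to the 3-nitrophenyl compound also holds for the second difluorophenyl group, with a 2.9-fold higher number from compound 1 to compound 3 (0.46 log units; beyond the scatter). No measurement here offers a cause for either step. The compounds shown leave open what an amine, a carboxylic acid or a methoxy group would do on the phenyl ring at this carbonyl carbon, and whether changes elsewhere on the shared core would shift the number.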